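Amide-nitrogen substituent series: from compound 2 to compound 4

The source may hold more compounds than are shown below. What is called first, only, known or untested is meant among the compounds shown, and "the series" means these compounds.

The three measured compounds share one core and differ only in the group on the amide-type nitrogen. Compound 1 `CCCCCCCCCCCC(=O)OC[C@H](CSC[C@@H](N)C(=O)NCCO)OC(=O)CCCCCCCCCCC` in an assay on HEK293 cells for agonist activity at Toll-like receptor 2 (Homo sapiens) (on this read-out higher numbers stand for an effect only at larger amounts of compound and lower numbers for an effect already at smaller amounts), gives 24 nM. Compound 3 `CCCCCCCCCCCC(=O)OC[C@H](CSC[C@@H](N)C(=O)NCCCCCCO)OC(=O)CCCCCCCCCCC` gives 33 nM; the step of a 1.4-fold higher number from compound 1 to compound 3 (0.14 log units; within the scatter) lies within the scatter. Compound 2 `CCCCCCCCCCCC(=O)OC[C@H](CSC[C@@H](N)C(=O)N[C@H](C)CO)OC(=O)CCCCCCCCCCC` gives 22200 nM and stands highest of the three numbers: the step of a 930-fold higher number from compound 1 to compound 2 (2.97 log units; beyond the scatter) and the step of a 670-fold lower number from compound 2 to compound 3 (2.83 log units; beyond the scatter) are both large and beyond the scatter, so the 1-(hydroxymethyl)ethyl group of compound 2 goes with the high number in this series.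

Compound 4 `CCCCCCCCCCCC(=O)OC[C@H](CSC[C@@H](N)C(=O)NCCOCCOS(=O)(=O)O)OC(=O)CCCCCCCCCCC` carries the change (2-(2-(sulfooxy)ethoxy)ethyl in place of 1-(hydroxymethyl)ethyl on an amide-type nitrogen). The step that bears most directly on it is a 670-fold lower number from compound 2 to compound 3 (2.83 log units; beyond the scatter), where the same 1-(hydroxymethyl)ethyl group left and an unbranched hydroxy-terminated chain entered; the step of a 930-fold higher number from compound 1 to compound 2 (2.97 log units; beyond the scatter) points the same way from the other side. The step of a 1.4-fold higher number from compound 1 to compound 3 (0.14 log units; within the scatter) shows that chain length between the nitrogen and the terminal oxygen matters little. A large step down in this assay is therefore expected, a 560-fold lower number from compound 2 to compound 4 (2.74 log units; beyond the scatter), landing compound 4 near compounds 1 and 3. Compound 4 is estimated at 40 nM, with a range from 8 nM to 250 nM.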

Compound 4, half-maximal effective concentration: 61 nM
The estimate for compound 4 lay 1.5-fold (0.18 log units) below the measured number; the measured number falls inside the stated range.
By their numbers in this assay, from the lowest: compounds 1, 3 and 4 (each within the scatter of the next, the first and the last beyond it); then compound 2.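

In this assay, the amide-type nitrogen carries the 2-(2-(sulfooxy)ethoxy)ethyl group, with 10 heavy atoms against 4 in 1-(hydroxymethyl)ethyl, and still shows a 360-fold lower number from compound 2 to compound 4 (2.56 log units; beyond the scatter), so the low numbers are not confined to simple hydroxy-terminated chains. Compound 4 stays within the scatter of the hexanol-type chain, a 1.8-fold higher number from compound 3 to compound 4 (0.27 log units; within the scatter), while extending the terminal oxygen of compound 1 with 2-(sulfooxy)ethyl gives only a modest change, a 2.5-fold higher number from compound 1 to compound 4 (0.41 log units; beyond the scatter); among the four compounds, compound 2 alone has the high number, and it alone carries a branched group with a defined stereocentre on this nitrogen. No measurement is available to explain why this position tolerates the sulfooxy-bearing chain.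

The compounds shown leave open whether the loss in compound 2 follows from the added methyl itself or from its configuration, which the opposite stereoisomer of the 1-(hydroxymethyl)ethyl group would separate. They also leave open whether a terminal oxygen is needed at all, a question that a plain hexyl chain, or a chain ending in a carboxylic acid or an amine, would address.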